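The source may report more compounds than this note shows. Statements on the series, on what has been measured and on what is new or still open speak of the compounds shown alone.

Three compounds share one core and differ only in the group carried on an aromatic nitrogen. Compound 1 `CC(C)=CCC1=C(OCc2cn(C3CCNCC3)nn2)C(=O)c2ccccc2C1=O` carries piperidin-4-yl there, and in an ADME assay on HepG2 cells (Homo sapiens) for cytotoxicity, read by MTT assay, with a stated time of 24 h (on this read-out lower numbers stand for higher toxicity in this test and higher numbers for lower toxicity in this test), compound 1 gives 570000 nM. Compound 2 `CC(C)=CCC1=C(OCc2cn(-c3ccccc3)nn2)C(=O)c2ccccc2C1=O` carries phenyl, and in this assay compound 2 gives 100000 nM. Compound 3 `CC(C)=CCC1=C(OCc2cn(-c3cccc(F)c3)nn2)C(=O)c2ccccc2C1=O` carries 3-fluorophenyl, and in this assay compound 3 gives 265000 nM. Among these three numbers compound 3 stands second highest: a 2.2-fold lower number from compound 1 to compound 3 (0.33 log units; beyond the scatter), while a 2.7-fold higher number from compound 2 to compound 3 (0.42 log units; beyond the scatter). Compound 4 `CC(C)=CCC1=C(OCc2cn(-c3ccc(C#N)cc3)nn2)C(=O)c2ccccc2C1=O` has not yet been measured; it differs from compound 3 by 4-cyanophenyl in place of 3-fluorophenyl on an aromatic nitrogen. Among the compounds with values here, the step that bears on it most closely is the one within the phenyl pair, a 2.7-fold higher number from compound 2 to compound 3 (0.42 log units; beyond the scatter), which shows that a single substituent on the phenyl moved the number modestly upward; a 5.7-fold lower number from compound 1 to compound 2 (0.76 log units; beyond the scatter) concerns a different exchange and bears less. Within the data shown here, with only one such step to go on, the size of the coming change is uncertain, and the expected step is a 1.3-fold lower number from compound 3 to compound 4 (0.12 log units; within the scatter). Compound 4 is therefore estimated at 200000 nM, within a range of 70000 nM to 600000 nM.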

Compound 4, half-maximal cytotoxic concentration: 707000 nM
Beside the measured number, compound 4's estimate is 3.5-fold (0.55 log units) below it; the whole stated range lies below it.
By their numbers in this assay, from the lowest: compound 2; then compound 3; then compounds 1 and 4 (each within the scatter of the next).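

In this assay the cyano group on the phenyl ring gives a 7.1-fold higher number from compound 2 to compound 4 (0.85 log units; beyond the scatter) in a larger rise than the 3-fluorophenyl group gave, and exchanging the two substituted rings gives a 2.7-fold higher number from compound 3 to compound 4 (0.43 log units; beyond the scatter) as a further rise. Both substituted phenyl groups shown therefore stand above plain phenyl, but by different amounts, and here the group and its place on the ring change together. There is also a 1.2-fold higher number from compound 1 to compound 4 (0.09 log units; within the scatter) within the scatter, so an aromatic ring on this nitrogen need not give a lower number than piperidin-4-yl.

Nothing shown explains these differences. Going by these compounds, whether the cyano group or its place counts for more stays open, as does the outcome for a 3-cyanophenyl group, a 4-fluorophenyl group, or a phenyl ring carrying an amine or a carboxylic acid.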